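A Sulfone in Place of a Carboxamide at the Carbonyl

The compounds below may be only part of what the source reports. "The series", "measured", "known", "first", "only" and "open" are said of these compounds alone.

Compound 3 `NC(=O)c1ccc(C(=O)N2CCC(N(C3CC3)S(=O)(=O)c3cccc(C(F)(F)F)c3)CC2)cc1` carries a 4-carbamoylphenyl on a carbonyl carbon. In an assay on cells for inhibition of Voltage-dependent L-type calcium channel subunit alpha-1C (Homo sapiens), read by FLIPR and calcium flux, tested at 3 uM (a lower number here means a weaker effect, a higher number a stronger effect of the compound at the concentration tested), compound 3 gives 0%, the lower of the two numbers recorded. Its nearest neighbour is compound 1 `NC(=O)c1ccccc1C(=O)N1CCC(N(C2CC2)S(=O)(=O)c2cccc(C(F)(F)F)c2)CC1`, which in this assay gives 17%. The step of a number 17 percentage points lower from compound 1 to compound 3 (beyond the scatter) is beyond the scatter. For compound 2 `CS(=O)(=O)c1cccc(C(=O)N2CCC(N(C3CC3)S(=O)(=O)c3cccc(C(F)(F)F)c3)CC2)c1` the entry in this assay is "not determined" (no result reported), so no number is available for it.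

Compound 4 `CS(=O)(=O)c1ccccc1C(=O)N1CCC(N(C2CC2)S(=O)(=O)c2cccc(C(F)(F)F)c2)CC1` differs from compound 3 by 2-(methylsulfonyl)phenyl in place of 4-carbamoylphenyl on a carbonyl carbon. Among the compounds with values here, only one measured step bears on this change: a number 17 percentage points lower from compound 1 to compound 3 (beyond the scatter), which shows that 4-carbamoylphenyl in place of 2-carbamoylphenyl lowered the number, so a 2-substituted phenyl is the pattern of the higher value here. Within the data shown here, no measured step compares methylsulfonyl with carbamoyl, so the sulfone itself is untested. Compound 4 is therefore expected to rise by a number 15 percentage points higher from compound 3 to compound 4 (beyond the scatter), roughly reversing the earlier drop, with wide uncertainty. The estimate for compound 4 in this assay is 15%, within a range from 0% to 35%.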

Compound 4, a percentage reported as inhibition, at one concentration (the size of the read-out at that concentration, not a potency): 39%
For compound 4 the middle estimate is 24 percentage points below the measured one, and the stated range ends below it.
By their numbers in this assay, from the lowest: compound 3; then compound 1; then compound 4.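

In this assay, a number 22 percentage points higher from compound 1 to compound 4 (beyond the scatter), with methylsulfonyl in place of carbamoyl on an aromatic carbon, so the identity of this group matters and not only where it sits on the phenyl. The larger step, a number 39 percentage points higher from compound 3 to compound 4 (beyond the scatter), changes both the group and its place on the phenyl, which leaves compound 4 with the highest number of the three compounds. No measurement shown here explains the effect of the sulfone on this read-out.

On these data alone, it remains open whether another group in the same place, such as a nitrile or a carboxylic acid, would give a similar number, or whether a longer chain on the sulfone, such as ethylsulfonyl, would keep it. These numbers come from one tested concentration, so they leave the potency of compound 4 open.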